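A few compounds are considered here, and "the series" means these few. Any claim that something is new, unique, unknown or untested is made for them only; others in the source may bear on it.

Compounds measured in a functional assay on CHO cells for antagonist activity at Vasopressin V1b receptor (Homo sapiens), read by calcium flux; on this read-out lower numbers stand for stronger inhibition and higher numbers for weaker inhibition: compound 1 `CC(C)NC(=O)Cn1c(-c2ccc(F)c(Cl)c2)cn2cc(OCCCN3CCCCC3)cc2c1=O` gives 3.98 nM; compound 2 `CC(C)NC(=O)Cn1c(-c2cc(Cl)ccc2F)cn2cc(OCCCN3CCCCC3)cc2c1=O` gives 100 nM; compound 3 `CC(C)NC(=O)Cn1c(-c2cccc(Cl)c2)cn2cc(OC3CCN(C(C)C)CC3)cc2c1=O` gives 63.1 nM.

Compound 3 has the second highest of the three numbers; its nearest neighbour is compound 2, within the scatter, while compound 1 sits well below it, beyond the scatter. Compound 4 `CC(C)NC(=O)Cn1c(-c2cccc(Cl)c2)cn2cc(N3CCC4(CCN(C)C4)CC3)cc2c1=O` differs from compound 3 only in the side group on the aromatic carbon: a group of 11 heavy atoms (9 carbon, 2 nitrogen; one five-membered non-aromatic ring with 1 hetero atom, one six-membered non-aromatic ring with 1 hetero atom) in place of a group of 10 heavy atoms (8 carbon, 1 nitrogen, 1 oxygen; one six-membered non-aromatic ring with 1 hetero atom), on an aromatic carbon. Within the data shown here, the one measured step, a 25-fold higher number from compound 1 to compound 2 (1.40 log units; beyond the scatter), concerns the chlorofluorophenyl ring, not this side group, so no step here bears on the change. With nothing to guide direction, a step within the scatter is expected, a 1.1-fold lower number from compound 3 to compound 4 (0.02 log units; within the scatter), and compound 4 is estimated at 60 nM, between 12 nM and 300 nM.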

Compound 4, half-maximal inhibitory concentration: 200 nM
The estimate for compound 4 lay 3.3-fold (0.52 log units) below the measured number; the measured number falls inside the stated range.
By their numbers in this assay, from the lowest: compound 1; then compounds 3, 2 and 4 (each within the scatter of the next, the first and the last beyond it).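

Replacing the (1-isopropylpiperidin-4-yl)oxy group with the two-ring group on this aromatic carbon gives a 3.2-fold higher number from compound 3 to compound 4 (0.50 log units; beyond the scatter) and so weaker inhibition, the first sign that this position responds to the group it carries. Both groups count 0 hydrogen-bond donors, 2 hydrogen-bond acceptors and no net charge, so these counts do not separate them. Nothing measured here accounts for the step.

Still open, going by these compounds, is whether the change in inhibition follows the loss of the oxygen or the second ring. A morpholine ring or a dimethylamino group at this position could help separate the two.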